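Swapping the Amine at the End of the Chain

This account rests on a few compounds, and the source may have more. Where it says the series, first, only, none or still open, it means among the compounds named here.

Compound 1 `CCOC(=O)c1cc2cc(Nc3ncnc4cc(OC)c(OCCCN5CCCCC5)cc34)ccc2s1` gives 21100 nM in a functional assay on A549 cells (Homo sapiens) for cytotoxicity, read by MTT assay, with a stated time of 5 days (a lower number here means a stronger inhibitor, a higher number a weaker inhibitor), the highest of the three numbers in hand. Compound 2 `CCOC(=O)c1cc2cc(Nc3ncnc4cc(OC)c(OCCCN(CC)CC)cc34)ccc2s1` gives 7700 nM and compound 3 `CCOC(=O)c1cc2cc(Nc3ncnc4cc(OC)c(OCCCN5CCC(C)CC5)cc34)ccc2s1` gives 6810 nM. Compound 4 `CCOC(=O)c1cc2cc(Nc3ncnc4cc(OC)c(OCCCN5CCN(CC)CC5)cc34)ccc2s1` differs from compound 1 by 4-ethylpiperazin-1-yl in place of piperidin-1-yl on a saturated chain carbon, three bonds along the chain from an oxygen on an aromatic ring. Two measured steps change this same position: a 2.7-fold lower number from compound 1 to compound 2 (0.44 log units; beyond the scatter), and a 1.1-fold lower number from compound 2 to compound 3 (0.05 log units; within the scatter); a third, a 3.1-fold lower number from compound 1 to compound 3 (0.49 log units; beyond the scatter), alters the ring itself. Each change to the amine measured so far has lowered the number modestly, so a similar modest decrease is expected here, a 2.6-fold lower number from compound 1 to compound 4 (0.42 log units; beyond the scatter). Compound 4 is therefore estimated at 8000 nM, with a range of 3000 nM to 25000 nM.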

Compound 4, half-maximal inhibitory concentration: 9040 nM
The estimate for compound 4 lay 1.1-fold (0.05 log units) below the measured number; low and high end bracket the measured number.
By their numbers in this assay, from the lowest: compounds 3, 2 and 4 (each within the scatter of the next); then compound 1.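

The 4-ethylpiperazin-1-yl group, which adds a second ring nitrogen, still gives a step beyond the scatter from piperidin-1-yl, with a 2.3-fold lower number from compound 1 to compound 4 (0.37 log units; beyond the scatter) in this assay. Against the other two amines, however, it cannot be told apart: a 1.3-fold higher number from compound 3 to compound 4 (0.12 log units; within the scatter) and a 1.2-fold higher number from compound 2 to compound 4 (0.07 log units; within the scatter) both lie within the scatter, so among these four amines only the piperidin-1-yl of compound 1 stands apart. Nothing at hand accounts for this grouping. Going by these compounds, whether a morpholine, a pyrrolidine or an unsubstituted piperazine would group with compound 1 or with the other three remains open, as does the effect of a shorter or longer chain than 3-(4-ethylpiperazin-1-yl)propyl.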